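Cytotoxicity notes: fluoro in place of cyano

This account rests on a few compounds, and the source may have more. Where it says the series, first, only, none or still open, it means among the compounds named here.

Compound 1 `Cc1ccc(C2=NN(c3nc(-c4ccc(F)cc4)cs3)C(c3ccc(F)cc3)C2)s1` gives in an ADME assay on NIH3T3 cells (Mus musculus) for cytotoxicity, read by XTT assay, with a stated time of 24 h (a lower number here means a stronger inhibitor, a higher number a weaker inhibitor), only a limit, > 500 ug/mL. Compound 2 `N#Cc1ccc(-c2csc(N3N=C(c4ccc(Cl)s4)CC3c3ccc(F)cc3)n2)cc1` likewise returns only a limit in this assay, > 500 ug/mL. Compound 2 therefore stands where both shown values sit, namely (the limit of > 500 ug/mL in this assay, at which 2 of the 2 values shown sit). Compound 3 `Fc1ccc(-c2csc(N3N=C(c4ccc(Cl)s4)CC3c3ccc(F)cc3)n2)cc1` differs from compound 2 by fluoro in place of cyano on an aromatic carbon. Going by the values given here, no measured step exists for this change, so the expected step that the limit leaves unreadable from compound 2 to compound 3 is none beyond the scatter. Compound 3 is accordingly estimated at 600 ug/mL, with a range from 300 ug/mL to 2000 ug/mL, most likely again reported only as a limit.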

Compound 3, half-maximal inhibitory concentration: > 500 ug/mL
Compound 3 gave a limit, no number (the forecaster's own chance of this, stated with the estimate: 85%); the middle value does not contradict the limit.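

Compound 3 joins compound 1 and compound 2 at a limit of the assay, so no step among them can be read: the limit of > 500 ug/mL in this assay, at which 3 of the 3 values shown sit.

The compounds shown leave open whether fluoro, cyano, chloro and methyl differ at all in this assay.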